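Benzyl swap on the sulfanyl arm: expected microsomal half-life

The source may hold more compounds than are shown below. What is called first, only, known or untested is meant among the compounds shown, and "the series" means these compounds.

Two members of the series have been run in an ADME assay on microsomes from liver (Homo sapiens) for metabolic stability, read by LC-MS, using NADPH, tested at 5 uM; on this read-out higher numbers stand for a longer-lived compound and lower numbers for a shorter-lived compound. Compound 2, `Cc1cc(S(=O)(=O)/N=C(\N)n2nccc2-c2ccccc2)c(SCc2ccccc2C(F)(F)F)cc1Cl`, gives 0.15 h in this assay. Compound 1, `Cc1cc(-c2ccccc2)n(/C(N)=N/S(=O)(=O)c2cc(C)c(Cl)cc2SCc2ccc(Cl)cc2)n1`, gives 0.24 h in this assay. The two numbers lie within the usual scatter of each other, so neither can be set above the other on these data.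

Compound 3, `Cc1cc(S(=O)(=O)/N=C(\N)n2nccc2-c2ccccc2)c(SCc2ccc(Cl)cc2)cc1Cl`, has not been measured. It differs from compound 2 in one place: 4-chlorophenyl in place of 2-(trifluoromethyl)phenyl on a saturated chain carbon bound to a sulfur. Compound 1 carries the same 4-chlorobenzyl on its sulfur, though on a differently arranged core, and its value in this assay sits close to that of compound 2; nothing shown points to a move beyond the scatter for this change.

Compound 3 is therefore expected to land near the two measured numbers, with an estimated step from compound 2 of a 1.3-fold higher number from compound 2 to compound 3 (0.12 log units; within the scatter), that is, no change beyond the scatter in either direction. The estimate for compound 3 in this assay is 0.2 h, with a range from 0.1 h to 0.4 h.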

Compound 3, half-life: 0.34 h
For compound 3 the middle estimate is 1.7-fold (0.23 log units) below the measured one; measured number inside the range.
By their numbers in this assay, from the lowest: compounds 2, 1 and 3 (each within the scatter of the next, the first and the last beyond it).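

In this assay, among these compounds, 4-chlorophenyl in place of 2-(trifluoromethyl)phenyl on a saturated chain carbon bound to a sulfur gives a 2.3-fold higher number from compound 2 to compound 3 (0.36 log units; beyond the scatter); this is the first single-place comparison, and it shows that the half-life can respond, modestly, to the group carried on this arm. With the 4-chlorobenzyl held constant, hydrogen in place of methyl on an aromatic carbon reads a 1.4-fold higher number from compound 1 to compound 3 (0.15 log units; within the scatter), so this pair does not separate the two groups on this read-out. Nothing shown gives a measured reason for the step at the sulfanyl arm.

A single pair cannot show whether the step belongs to the loss of the 2-(trifluoromethyl)phenyl or to the arrival of the 4-chlorophenyl, and a plain benzyl or a 4-(trifluoromethyl)benzyl on the same sulfur would begin to divide the two. Going by these compounds, it also remains open whether a polar group on this ring, such as a carboxylic acid or an amine, would move the half-life further than the halogen and trifluoromethyl groups seen so far.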